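This account rests on a few compounds, and the source may have more. Where it says the series, first, only, none or still open, it means among the compounds named here.

Measured in a functional assay on MCF7 cells (Homo sapiens) for inhibition, with a stated time of 48 h; on this read-out lower numbers stand for stronger inhibition and higher numbers for weaker inhibition:
- compound 1 `COc1cc(Sc2c[nH]c3ccc(N)cc23)cc(OC)c1OC`: 260 nM
- compound 2 `COc1ccc2[nH]cc(Sc3cc(OC)c(OC)c(OC)c3)c2c1`: 22 nM

Of these two, compound 2 holds the lowest number, at 22 nM. Compound 3 `COc1cc(Sc2c[nH]c3ccc(OCCO)cc23)cc(OC)c1OC` alters its methoxy, turning it into 2-hydroxyethoxy: hydroxymethyl in place of hydrogen on a saturated chain carbon bound to an oxygen on an aromatic ring. Going by the values given here, only one measured step bears on this, a 12-fold lower number from compound 1 to compound 2 (1.07 log units; beyond the scatter), where methoxy took the place of amino. Among the compounds with values here, it shows that a swap at this group can matter, but no measured compound carries a longer chain there, so the evidence is thin. A moderate move toward a higher number is expected, an estimated 3.2-fold higher number from compound 2 to compound 3 (0.50 log units; beyond the scatter). Compound 3 is estimated at 70 nM, with an expected range of 20 nM to 250 nM.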

Compound 3, half-maximal inhibitory concentration: 95 nM
The estimate for compound 3 lay 1.4-fold (0.13 log units) below the measured number, within the range that was stated.
By their numbers in this assay, from the lowest: compound 2; then compound 3; then compound 1.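

In this assay, lengthening methoxy to 2-hydroxyethoxy weakens inhibition, with a 4.3-fold higher number from compound 2 to compound 3 (0.64 log units; beyond the scatter), so this position accepts the longer group but gains nothing from it. The new group still outperforms amino, with a 2.7-fold lower number from compound 1 to compound 3 (0.44 log units; beyond the scatter), which places 2-hydroxyethoxy between methoxy and amino among these three compounds. Nothing measured here explains why the added hydroxymethyl has this effect.

Still open, going by these compounds, is whether the added length or the end hydroxyl drives the change, a question an ethoxy group could help separate. On these data alone, how a 3-hydroxypropoxy or 2-aminoethoxy chain would compare also remains unknown.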